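This account rests on a few compounds, and the source may have more. Where it says the series, first, only, none or still open, it means among the compounds named here.

Measured so far:
compound 1, `O=C(CCN1C(=O)CSc2ccccc21)NCCCN1CCN(c2ccc([N+](=O)[O-])cc2)CC1`, gives > 100000 nM in a functional assay (MiaPaCa cells, Homo sapiens) for inhibition, read by sulforhodamine B assay, with a stated time of 48 h; a lower number here means a stronger inhibitor of growth, a higher number a weaker inhibitor of growth; this value is a limit of the assay.
compound 2, `COc1ccccc1N1CCN(CCCNC(=O)CCN2C(=O)CSc3ccccc32)CC1`, gives 59200 nM in this assay.

Compound 2 holds the only finite number shown; the other value is a limit (the limit of > 100000 nM in this assay, at which 1 of the 2 values shown sits). Among the compounds with values here, the single measured step, an at least 1.6-fold lower number from compound 1 to compound 2 (0.22 log units; that floor lies within the scatter), therefore has a floor that sits inside the usual scatter, so the two compounds cannot be ranked with confidence.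

Compound 3, `O=C(CCN1C(=O)CSc2ccccc21)NCCCN1CCN(c2ccc(C(F)(F)F)cc2)CC1`, differs from compound 2 in one place: 4-(trifluoromethyl)phenyl in place of 2-methoxyphenyl on an amine nitrogen in a ring. Within the data shown here, the only step that bears on this change is the exchange at the same ring nitrogen from compound 1 to compound 2, an at least 1.6-fold lower number from compound 1 to compound 2 (0.22 log units; that floor lies within the scatter), and it is small at its floor. The entering 4-(trifluoromethyl)phenyl shares the substitution pattern of the 4-nitrophenyl in compound 1 rather than that of the 2-methoxyphenyl, so no move beyond the scatter is expected in this assay, with some chance of a weaker result that returns only a limit.

Compound 3 is expected at 80000 nM, within 30000 nM to 300000 nM, a step of a 1.4-fold higher number from compound 2 to compound 3 (0.13 log units; within the scatter) that is estimated to stay within the scatter.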

Compound 3, concentration for 50% growth inhibition: > 100000 nM
Compound 3: only a limit was reported; the forecaster's own chance of this, stated with the estimate: 40%; middle value at least 1.2-fold (0.09 log units) from the limit.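

Compound 3 returns only a limit in this assay, not a number, so 4-(trifluoromethyl)phenyl on the ring nitrogen joins the 4-nitrophenyl of compound 1 at the same limit: the limit of > 100000 nM in this assay, at which 2 of the 3 values shown sit.

Exchanging 2-methoxyphenyl for 4-(trifluoromethyl)phenyl gives an at least 1.6-fold higher number from compound 2 to compound 3 (0.22 log units; that floor lies within the scatter), so this change, like the earlier one at the same nitrogen, does not rank its two compounds with confidence. The step between the two limits cannot be read, which leaves nitro and trifluoromethyl on the aromatic carbon undistinguished; the only observation is that both groups bearing a 4-substituent sit at the limit, while the 2-methoxyphenyl of compound 2 gives a finite number, a separation whose floor stays within the scatter.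

An unsubstituted phenyl or a 4-methoxyphenyl on the same nitrogen would show whether the substituent's place or its identity matters here. On these data alone, compound 2 gives 59200 nM, and also open is whether any other group at this position, such as a pyridine ring or a phenyl carrying a carboxylic acid, would move the series beyond the scatter.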